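Aryl amine variations on a fused tricyclic core

The source may hold more compounds than are shown below. What is called first, only, known or untested is meant among the compounds shown, and "the series" means these compounds.

Compound 3 `O=C1C(Nc2ccc(Br)cc2)=CC(=O)c2c1nc1n2[C@H]2OC[C@@H](O)[C@H]2OC1` is one of three measured members of this set. In a functional assay on MGC-803 cells (Homo sapiens) for inhibition, read by sulforhodamine B assay (a lower number here means a stronger inhibitor, a higher number a weaker inhibitor), compound 3 gives 2020 nM, and compound 1 `CCOc1ccc(NC2=CC(=O)c3c(nc4n3[C@H]3OC[C@@H](O)[C@H]3OC4)C2=O)cc1` gives 2090 nM, so the two sit together, a 1.0-fold lower number from compound 1 to compound 3 (0.01 log units; within the scatter). Compound 2 `O=C1C(NC2CCCC2)=CC(=O)c2c1nc1n2[C@H]2OC[C@@H](O)[C@H]2OC1` reaches only a limit of this assay, > 16000 nM. The step of an at least 7.9-fold lower number from compound 2 to compound 3 (0.89 log units; beyond the scatter) shows that an aryl group on the amine nitrogen carries the activity, and an at least 7.6-fold higher number from compound 1 to compound 2 (0.88 log units; beyond the scatter) points the same way; the limit itself is told by the limit of > 16000 nM in this assay, at which 1 of the 3 values shown sits.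

Compound 4 `O=C1C(Nc2cccc(F)c2)=CC(=O)c2c1nc1n2[C@H]2OC[C@@H](O)[C@H]2OC1` differs from compound 3 by 3-fluorophenyl in place of 4-bromophenyl on an amine nitrogen. Among the measured compounds shown here, the only measured step that alters a substituent on the aryl ring, a 1.0-fold lower number from compound 1 to compound 3 (0.01 log units; within the scatter), is flat, and no measured step moves a substituent around the ring, so there is no guidance on that part of the change. The aryl ring itself stays in place, which the steps from compound 2 mark as the decisive feature. Compound 4 is therefore expected to show a 1.1-fold higher number from compound 3 to compound 4 (0.06 log units; within the scatter), a step within the scatter. The expected value for compound 4 is 2300 nM, estimated to lie between 800 nM and 6500 nM.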

Compound 4, half-maximal inhibitory concentration: 1470 nM
Compound 4: middle estimate off by 1.6-fold (0.19 log units), on the high side, within the range that was stated.
By their numbers in this assay, from the lowest: compounds 4, 3 and 1 (each within the scatter of the next). At a limit, above all of these: compound 2.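

The aryl group on the amine nitrogen can change without any shift beyond the scatter in this assay, as 3-fluorophenyl gives a 1.4-fold lower number from compound 3 to compound 4 (0.14 log units; within the scatter) and, against 4-ethoxyphenyl, a 1.4-fold lower number from compound 1 to compound 4 (0.15 log units; within the scatter). The contrast with the cyclopentyl group holds for this third aryl group as well and is the widest shown here, with an at least 10-fold lower number from compound 2 to compound 4 (1.03 log units; beyond the scatter). That step is only a bound, since compound 2 stands at a limit of the assay: the limit of > 16000 nM in this assay, at which 1 of the 4 values shown sits.

Among the compounds shown here, the one step between compound 3 and compound 4 replaces the halogen and alters its ring position together, so the two changes cannot be separated. As far as these compounds go, whether 4-fluorophenyl, 3-bromophenyl or a phenyl ring carrying an amine or a carboxylic acid would stay at this level remains open.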